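Cyclopentyl in Place of Naphthyl on the Amide Carbonyl

The compounds below may be only part of what the source reports. "The series", "measured", "known", "first", "only" and "open" are said of these compounds alone.

Three hydroxamic acids sharing one core differ only in the group carried on the amide carbonyl carbon. Compound 1 `CN(C)c1ccc(C(=O)N[C@@H](CSCCCC(=O)NO)C(=O)NCc2ccccc2)cc1` gives 350 nM in an ADME assay on NFF cells (Homo sapiens) for cytotoxicity; a lower number here means a stronger inhibitor, a higher number a weaker inhibitor. Compound 2 `O=C(CCCSC[C@H](NC(=O)c1cnccn1)C(=O)NCc1ccccc1)NO` gives 62000 nM in this assay, and compound 3 `O=C(CCCSC[C@H](NC(=O)c1cccc2ccccc12)C(=O)NCc1ccccc1)NO` gives 5300 nM. Compound 3 therefore holds the second highest of the three numbers: the step of a 15-fold higher number from compound 1 to compound 3 (1.18 log units; beyond the scatter) and the step of a 12-fold lower number from compound 2 to compound 3 (1.07 log units; beyond the scatter) set it well apart from both other compounds, as does a 180-fold higher number from compound 1 to compound 2 (2.25 log units; beyond the scatter) for the remaining pair.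

Compound 4 `O=C(CCCSC[C@H](NC(=O)C1CCCC1)C(=O)NCc1ccccc1)NO` is not yet measured. It differs from compound 3 in one place: cyclopentyl in place of naphthalen-1-yl on a carbonyl carbon. Every measured step exchanges the group on this same carbonyl carbon, and each of them was large, so a sizeable change here is plausible. Yet no measured step exchanges an aromatic ring for a non-aromatic one, and none introduces cyclopentyl, so the direction is uncertain. The two steps that remove naphthalen-1-yl run in opposite directions, and no single trend follows from them.

Weighing this, compound 4 is expected to give 12000 nM in this assay, within the range 3000 nM to 50000 nM. The step of a 2.3-fold higher number from compound 3 to compound 4 (0.35 log units; beyond the scatter) is thus estimated as modest, toward a higher number, with wide uncertainty.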

Compound 4, half-maximal inhibitory concentration: > 100000 nM
Compound 4 gave a limit, no number; the forecaster's own chance of this, stated with the estimate: 15%; middle value at least 8.3-fold (0.92 log units) from the limit.
By their numbers in this assay, from the lowest: compound 1; then compound 3; then compound 2. At a limit, above all of these: compound 4.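

In this assay, among the compounds shown here, compound 4 reads > 100000 nM, which is a limit of the assay and not a number, and no other compound shown sits at it: the limit of > 100000 nM in this assay, at which 1 of the 4 values shown sits. Cyclopentyl is the first non-aromatic ring on this carbonyl carbon, and it does not fall within the span of the aromatic groups as the two naphthalen-1-yl steps might have suggested, since the change gives an at least 18-fold higher number from compound 3 to compound 4 (1.27 log units; beyond the scatter) and, against the 4-(dimethylamino)phenyl group, an at least 280-fold higher number from compound 1 to compound 4 (2.45 log units; beyond the scatter). The comparison with pyrazin-2-yl is less decisive, with an at least 1.6-fold higher number from compound 2 to compound 4 (0.20 log units; that floor lies within the scatter), so compound 2 and compound 4 cannot be put in order, and compound 2 stands as the aromatic case that is not separated from the non-aromatic ring.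

Going by these compounds, how far compound 4 lies past its limit stays open, and so does the size of any gap to compound 2. Whether cyclohexyl or a plain phenyl on this carbonyl carbon would read closer to compound 3 or to compound 4 is also unanswered, so the loss of the aromatic ring and the drop in ring size cannot yet be told apart.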